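The source may report more compounds than this note shows. Statements on the series, on what has been measured and on what is new or still open speak of the compounds shown alone.

- compound 1 `COC(=O)c1ccc(C(=O)Nc2cccc(-c3cc(=O)c4c(OC)c(OC)c(OC)cc4o3)c2)cc1`: 30300 nM
- compound 2 `COc1ccc(C(=O)Nc2cccc(-c3cc(=O)c4c(OC)c(OC)c(OC)cc4o3)c2)cc1`: 6870 nM

In a functional assay on MCF7 cells (Homo sapiens) for inhibition, read by MTT assay (a higher number here means a weaker inhibitor of growth, a lower number a stronger inhibitor of growth), compound 2 has the lower of the two numbers, at 6870 nM, so it is the stronger inhibitor of growth measured so far. Compound 3 `COc1ccccc1C(=O)Nc1cccc(-c2cc(=O)c3c(OC)c(OC)c(OC)cc3o2)c1` differs from it in one place: 2-methoxyphenyl in place of 4-methoxyphenyl on a carbonyl carbon. In words, 2-methoxyphenyl stands in place of 4-methoxyphenyl on a carbonyl carbon. Among the measured compounds shown here, only one measured step bears on this: a 4.4-fold lower number from compound 1 to compound 2 (0.64 log units; beyond the scatter), a modest change made by putting methoxy in place of methoxycarbonyl on an aromatic carbon. For the measured compounds named here, that step shows that a change on this aromatic ring can move the number, but no measured pair tests this exact change, so the direction remains uncertain. Since compound 2 sits at the better end at 6870 nM, a modest rise is expected, as a 1.5-fold higher number from compound 2 to compound 3 (0.16 log units; within the scatter). For compound 3, the estimated value is 10000 nM, with an expected range of 3500 nM to 30000 nM.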

Compound 3, concentration for 50% growth inhibition: 15300 nM
For compound 3 the middle estimate is 1.5-fold (0.18 log units) below the measured one, and the stated range covers the measured number.
By their numbers in this assay, from the lowest: compound 2; then compounds 3 and 1 (each within the scatter of the next).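

In this assay, moving the methoxy group with no change in atoms gives a 2.2-fold higher number from compound 2 to compound 3 (0.35 log units; beyond the scatter), so the number depends on where the methoxy group stands on this ring and not only on which group is present. Replacing 4-(methoxycarbonyl)phenyl with 2-methoxyphenyl gives a 2.0-fold lower number from compound 1 to compound 3 (0.30 log units; within the scatter), so compound 1 and compound 3 cannot be told apart, and a methoxy group on this ring does not by itself give the stronger inhibitor of growth. Nothing measured here explains the effect of moving the group.

The compounds shown leave open how an amine, a carboxylic acid or an ethoxy group would behave on this ring. They also leave open whether any group there could bring the number well below that of compound 2 at 6870 nM.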